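This account rests on a few compounds, and the source may have more. Where it says the series, first, only, none or still open, it means among the compounds named here.

Compound 3 `CN1[C@@H]2c3[nH]c4ccccc4c3C[C@H]1[C@H](C#N)N1[C@@H](CNC(=O)c3ccc4ccccc4c3)c3[nH]c4ccccc4c3C[C@@H]21` gives the highest of the three numbers in a functional assay on HT-29 cells (Homo sapiens) for cytotoxicity, read by MTT assay, with a stated time of 72 h (on this read-out lower numbers stand for stronger inhibition and higher numbers for weaker inhibition), namely 4940 nM. In this assay compound 1 `CN1[C@@H]2c3[nH]c4ccccc4c3C[C@H]1[C@H](C#N)N1[C@@H](CNC(=O)c3ccc(Cl)cc3)c3[nH]c4ccccc4c3C[C@@H]21` gives 130 nM, and compound 2 `COc1ccc(C(=O)NC[C@H]2c3[nH]c4ccccc4c3C[C@H]3[C@H]4c5[nH]c6ccccc6c5C[C@@H]([C@H](C#N)N23)N4C)cc1` gives 840 nM. Both steps leading to compound 3 alter the group on the carbonyl carbon, and both were sizable: a 38-fold higher number from compound 1 to compound 3 (1.58 log units; beyond the scatter) and a 5.9-fold higher number from compound 2 to compound 3 (0.77 log units; beyond the scatter). Compound 4 `CN1[C@@H]2c3[nH]c4ccccc4c3C[C@H]1[C@H](C#N)N1[C@@H](CNC(=O)c3cc4ccccc4s3)c3[nH]c4ccccc4c3C[C@@H]21` changes that same place once more: 1-benzothiophen-2-yl in place of naphthalen-2-yl on a carbonyl carbon. Within the data shown here, no measured step exchanges one fused two-ring group for another, so the earlier steps show only that this position can move the number strongly, not which way this swap goes. Compound 4 is therefore expected to stay near its parent, with a 1.6-fold lower number from compound 3 to compound 4 (0.22 log units; within the scatter). For compound 4 the estimate in this assay is 3000 nM, with a range from 800 nM to 12000 nM.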

Compound 4, half-maximal inhibitory concentration: 640 nM
Estimate against measurement, compound 4: 4.7-fold (0.67 log units) above; measured number outside the range, below it.
By their numbers in this assay, from the lowest: compound 1; then compounds 4 and 2 (each within the scatter of the next); then compound 3.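

In this assay, the swap of fused two-ring groups on the carbonyl carbon still moves the number (a 7.7-fold lower number from compound 3 to compound 4 (0.89 log units; beyond the scatter)), so having two fused rings does not by itself decide the result at this position. The 1-benzothiophen-2-yl and 4-methoxyphenyl groups cannot be told apart here (a 1.3-fold lower number from compound 2 to compound 4 (0.12 log units; within the scatter)), while 4-chlorophenyl keeps the lowest number (a 4.9-fold higher number from compound 1 to compound 4 (0.69 log units; beyond the scatter)). Nothing available explains the difference between 1-benzothiophen-2-yl and naphthalen-2-yl. Still open, from the compounds shown here alone, is how a non-aromatic group on this carbonyl carbon, such as a piperidine or a carboxylic acid-bearing chain, would compare.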